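This account rests on a few compounds, and the source may have more. Where it says the series, first, only, none or still open, it means among the compounds named here.

Compound 1 `C=CC(=O)Oc1cc(C(F)(F)F)cc(C(F)(F)F)c1` — < 0.017 h
Compound 2 `C=CS(=O)(=O)c1cc(C(F)(F)F)cc(C(F)(F)F)c1` — < 0.017 h
Compound 3 `O=C1C=CC(=O)N1c1cc(C(F)(F)F)cc(C(F)(F)F)c1` — < 0.017 h

In an ADME assay for pharmacokinetics, read by LC-MS, in phosphate buffer, with a stated time of 72 h, at pH 7.4, tested at 250 uM (a lower number here means that the compound disappears faster, a higher number that the compound lasts longer), compound 3 gives < 0.017 h, a limit of the assay rather than a number. Compound 1 and compound 2 sit at the same limit, so that the limit of < 0.017 h in this assay, at which 3 of the 3 values shown sit, covers all three. Compound 4 `N#Cc1cc(C(F)(F)F)cc(C(F)(F)F)c1` differs from compound 3 by a group of 2 heavy atoms (1 carbon, 1 nitrogen; no ring) in place of a group of 7 heavy atoms (4 carbon, 1 nitrogen, 2 oxygen; one five-membered non-aromatic ring with 1 hetero atom), on an aromatic carbon. Among the compounds with values here, the steps that touch compound 3 are a step that the two limits leave unreadable from compound 1 to compound 3 and a step that the two limits leave unreadable from compound 2 to compound 3, and both stay hidden behind the limits, so they give no size for the step ahead. The expectation for compound 4 therefore rests on the structural change alone, and compound 4 is expected to reach 200 h in this assay, within 20 h to 2000 h. That estimate means a step of an at least 11000-fold higher number from compound 3 to compound 4 (4.07 log units; beyond the scatter) from compound 3 to compound 4, expected to run upward.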

Compound 4, half-life: 50 h
The estimate for compound 4 lay 4.0-fold (0.60 log units) above the measured number; the range from low to high includes it.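

Within the data shown here, on the shared core, cyano is the first group at this position to give a number in this assay and not a limit. Cyano gives an at least 2900-fold higher number from compound 3 to compound 4 (3.46 log units; beyond the scatter), an at least 2900-fold higher number from compound 2 to compound 4 (3.46 log units; beyond the scatter) and an at least 2900-fold higher number from compound 1 to compound 4 (3.46 log units; beyond the scatter). The steps among compound 1, compound 2 and compound 3 cannot be read, and only compound 4 stands clear of the limit: the limit of < 0.017 h in this assay, at which 3 of the 4 values shown sit.

As far as these compounds go, how long an amine or a carboxylic acid would last at this position stays open. So does whether cyano gives a similar number on another core.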